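From 4-methylphenyl to 1-methyl-1H-indol-5-yl

A few compounds are considered here, and "the series" means these few. Any claim that something is new, unique, unknown or untested is made for them only; others in the source may bear on it.

Compound 1 `COc1cc(-c2cc3nccc(-c4cc(OC)c(OC)c(OC)c4)n3n2)cc(OC)c1OC`: > 10000 nM
Compound 2 `COc1cc(-c2cc3nccc(-c4c[nH]c5ccccc45)n3n2)cc(OC)c1OC`: > 10000 nM
Compound 3 `COc1cc(-c2ccnc3cc(-c4ccc(C)cc4)nn23)cc(OC)c1OC`: 21 nM

Going by the values given here, in a functional assay on B16-F0 cells (Mus musculus) for inhibition, read by CCK-8 assay, with a stated time of 48 h (on this read-out higher numbers stand for weaker inhibition and lower numbers for stronger inhibition), compound 3 gives 21 nM, the only true number in this small set. Compound 1 reaches only a limit of the assay, > 10000 nM. Compound 2 also reaches only a limit, > 10000 nM.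

Compound 4 `COc1cc(-c2ccnc3cc(-c4ccc5c(ccn5C)c4)nn23)cc(OC)c1OC` carries 1-methyl-1H-indol-5-yl in place of the 4-methylphenyl of compound 3, on an aromatic carbon of the five-membered ring: 1-methyl-1H-indol-5-yl in place of 4-methylphenyl on an aromatic carbon. Among the compounds with values here, no measured pair shows a change of this kind. Within the data shown here, with compound 3 at 21 nM as the only guide, a shift no larger than the usual scatter is expected in this assay, in neither direction. The expected change is a 1.2-fold higher number from compound 3 to compound 4 (0.08 log units; within the scatter). For compound 4 the estimate is 25 nM, with an expected range of 6 nM to 150 nM.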

Compound 4, half-maximal inhibitory concentration: 48 nM
Beside the measured number, compound 4's estimate is 1.9-fold (0.28 log units) below it; measured number inside the range.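

In this assay the change to 1-methyl-1H-indol-5-yl gives a 2.3-fold higher number from compound 3 to compound 4 (0.36 log units; beyond the scatter), a modest loss, so this aromatic carbon of the five-membered ring still accepts a group with two aromatic rings in place of 4-methylphenyl. Compound 1 and compound 2 stay at a limit of the assay and compound 4 does not: the limit of > 10000 nM in this assay, at which 2 of the 4 values shown sit.

The compounds shown leave open whether the loss comes from the added ring or from its ring nitrogen. They also leave open how an amine, a carboxylic acid or a longer chain would fare at this position.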